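The source may report more compounds than this note shows. Statements on the series, on what has been measured and on what is new or still open speak of the compounds shown alone.

Working notes on the series.

Compound 3 `CC(C(=O)N1CCN(c2ccccc2Cl)CC1)N1C(=O)CCC1=O` gives 0% in a functional assay on the whole organism (strain Swiss) with Mus musculus as the target, in the maximal electroshock model, with a stated time of 0.25 h, at a dose of 300 mg/kg by the intraperitoneal route (a higher number here means a stronger effect of the compound at the dose given, a lower number a weaker effect), and stands lowest of the three measured numbers. Compound 1 `CC(C(=O)N1CCN(c2cccc(F)c2)CC1)N1C(=O)CCC1=O` gives 100% in this assay, and compound 2 `Cc1cccc(N2CCN(C(=O)C(C)N3C(=O)CCC3=O)CC2)c1` gives 100%. The two steps reaching compound 3 are both large: a number 100 percentage points lower from compound 1 to compound 3 (beyond the scatter) and a number 100 percentage points lower from compound 2 to compound 3 (beyond the scatter), while no change at the digits printed from compound 1 to compound 2 (within the scatter).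

Compound 4 `CC(C(=O)N1CCN(c2ccccc2)CC1)N1C(=O)CCC1=O` is not yet measured. The change is hydrogen in place of chloro on an aromatic carbon. Among the measured compounds shown here, no measured step removes a substituent from the ring outright; the two steps that bear on it both replace a 3-fluorophenyl or 3-methylphenyl with 2-chlorophenyl and each drops by the full scale. The unsubstituted phenyl of compound 4 shares neither pattern, so the direction is taken from those two steps as a recovery of part of the lost activity, with wide uncertainty. Compound 4 is expected to give 60% in this assay, in the range 10% to 100%, an estimated step of a number 60 percentage points higher from compound 3 to compound 4 (beyond the scatter).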

Compound 4, a percentage reported as activity, at one dose (the size of the read-out at that dose, not a potency): 100%
Compound 4: the middle estimate sits 40 percentage points below what was measured, within the range that was stated.
By their numbers in this assay, from the lowest: compound 3; then compounds 1, 2 and 4 (each within the scatter of the next).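

Taking off the chloro restores the read-out in full, a number 100 percentage points higher from compound 3 to compound 4 (beyond the scatter), so within these compounds the loss follows the chloro on the aromatic ring and not the shared core. The unsubstituted phenyl also shows that the ring needs no substituent in this assay: the other two replacements give no change at the digits printed from compound 2 to compound 4 (within the scatter) and no change at the digits printed from compound 1 to compound 4 (within the scatter), so neither fluoro nor methyl is required at this dose. Nothing on hand gives a reason for the loss seen with chloro.

As far as these compounds go, whether the loss is specific to chloro or extends to other groups ortho to a large group, such as methyl, methoxy or a carboxylic acid, remains open. With a single dose, the read-out also cannot separate the potency of compound 1, compound 2 and compound 4.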